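The source may report more compounds than this note shows. Statements on the series, on what has been measured and on what is new or still open speak of the compounds shown alone.

Measured compounds:
compound 1, `Nc1scc(CN2CCN(c3ccncc3)CC2)c1C(=O)c1ccc(Cl)cc1`, giving -4% in a functional assay on CHO cells with adenosine receptor A1 (Homo sapiens) as the target, read by cAMP accumulation and immunoassay, with a stated time of 6 min, tested at 0.01 uM; on this read-out lower numbers stand for a stronger effect and higher numbers for a weaker effect at the one concentration tested
compound 2, `Nc1scc(CN2CCN(C3CCCCCC3)CC2)c1C(=O)c1ccc(Cl)cc1`, giving 2.9% in this assay

On these two numbers compound 2 stands next to compound 1, and the step of a number 6.9 percentage points higher from compound 1 to compound 2 (within the scatter) lies within the scatter, so nothing separates the two compounds at the concentration tested. That step, cycloheptyl in place of pyridin-4-yl on an amine nitrogen in a ring, is the only measured one and it bears on what follows only in that exchanging the group on this ring nitrogen left the read-out where it was.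

Compound 3, `Nc1scc(CN2CCN(CCCc3ccc(Cl)cc3)CC2)c1C(=O)c1ccc(Cl)cc1`, differs from compound 2 in one place: 3-(4-chlorophenyl)propyl in place of cycloheptyl on an amine nitrogen in a ring. Among the compounds with values here, since the single comparable step stayed within the scatter and both measured values sit close to no effect, no step beyond the scatter is expected in this assay in either direction. Compound 3 is accordingly estimated to give 2% in this assay, with a range from -12% to 16%. The expected step of a number 0.9 percentage points lower from compound 2 to compound 3 (within the scatter) is thus one that stays within the scatter.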

Compound 3, a percentage reported as activity, at one concentration (the size of the read-out at that concentration, not a potency): 0%
Beside the measured number, compound 3's estimate is 2 percentage points above it; measured number inside the range.
By their numbers in this assay, from the lowest: compounds 1, 3 and 2 (each within the scatter of the next).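

With compound 3, the group on this amine nitrogen in a ring has now been varied three ways, and this assay still does not separate the compounds: the exchange of cycloheptyl for 3-(4-chlorophenyl)propyl gives a number 2.9 percentage points lower from compound 2 to compound 3 (within the scatter), and the exchange of pyridin-4-yl for the same group gives a number 4 percentage points higher from compound 1 to compound 3 (within the scatter). The earlier pair compared a ring placed directly on this nitrogen with another such ring, whereas compound 3 carries a six-membered aromatic ring of carbon only, with chlorine, at the end of a propyl chain, so the read-out tolerates this longer group here as well as it did the two directly attached rings. Nothing available explains why the read-out holds across these three groups.

From the compounds shown here alone, what a methyl group, a hydroxyethyl chain or a carboxylic acid on this nitrogen would give in this assay remains open, as does the effect of any change to the shared core, which is the same in compound 1, compound 2 and compound 3. A read-out at a single concentration is also not a potency, so differences among these three compounds that would appear at lower concentrations cannot be ruled out.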